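The source may report more compounds than this note shows. Statements on the series, on what has been measured and on what is new or still open speak of the compounds shown alone.

Measured compounds in a functional assay on aorta (strain Wistar) for inhibition, with Thoracic aorta (Rattus norvegicus) as the target; a lower number here means a stronger inhibitor, a higher number a weaker inhibitor:
Compound 1, `CCOc1nc(-c2cc3ccccc3o2)cc(-c2ccc(Cl)cc2Cl)c1C#N`, gives 442000 nM.
Compound 2, `CCOc1nc(-c2cc3ccccc3o2)cc(-c2ccc(C)cc2)c1C#N`, gives 290000 nM.
Compound 3, `CCOc1nc(-c2cc3ccccc3o2)cc(-c2cc(OC)ccc2OC)c1C#N`, gives 327000 nM.

The three compounds share one core and differ only in the aryl group attached to one aromatic carbon of that core. Every step among them is small: a 1.5-fold lower number from compound 1 to compound 2 (0.18 log units; within the scatter), a 1.4-fold lower number from compound 1 to compound 3 (0.13 log units; within the scatter) and a 1.1-fold higher number from compound 2 to compound 3 (0.05 log units; within the scatter). Compound 3 holds the second highest of the three numbers, its nearest neighbour being compound 2 and its most distant compound 1, and both of those gaps sit within the scatter, so no order among the three can be read from this assay.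

Compound 4, `CCOc1nc(-c2cc3ccccc3o2)cc(-c2ccc(N(C)C)cc2)c1C#N`, is not yet measured. Its change from compound 3 is 4-(dimethylamino)phenyl in place of 2,5-dimethoxyphenyl on an aromatic carbon. The three measured steps all exchange the aryl group at this same carbon, and none of them moved the number beyond the scatter. On that basis a further exchange of the aryl group is expected to give no step beyond the scatter either, so the estimated step is a 1.0-fold higher number from compound 3 to compound 4 (0.00 log units; within the scatter). For compound 4 in this assay the expected value is 330000 nM, with a range from 150000 nM to 720000 nM.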

Compound 4, half-maximal inhibitory concentration: 338000 nM
Compound 4: the middle estimate sits 1.0-fold (0.01 log units) below what was measured; the measured number falls inside the stated range.
By their numbers in this assay, from the lowest: compounds 2, 3, 4 and 1 (each within the scatter of the next).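

In this assay, for the compounds shown here, 4-(dimethylamino)phenyl brings the first nitrogen-bearing aryl group to this carbon, opposite the ring nitrogen, and the number stays within the scatter of all three earlier aryl groups: against 2,5-dimethoxyphenyl (a 1.0-fold higher number from compound 3 to compound 4 (0.01 log units; within the scatter)), against 4-methylphenyl (a 1.2-fold higher number from compound 2 to compound 4 (0.07 log units; within the scatter)) and against 2,4-dichlorophenyl (a 1.3-fold lower number from compound 1 to compound 4 (0.12 log units; within the scatter)). The comparison with compound 2 is the narrowest of these, since only dimethylamino replaces methyl on an otherwise unchanged phenyl ring, and even this exchange of a carbon group for a nitrogen group gives no readable difference, so the tolerance seen among the earlier aryl groups now extends to a fourth. No measurement at hand offers a reason for this flat picture.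

As far as these compounds go, what remains open is whether a group of a different kind at this carbon, such as a carboxylic acid, a primary amine on a longer chain or a plain ethyl group in place of the aryl ring, would move the number beyond the scatter. From the compounds shown here alone, the nitrile, the ethoxy group and the 1-benzofuran-2-yl group are the same in all four compounds, so what an exchange at any of those places would do also stays open.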